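This account rests on a few compounds, and the source may have more. Where it says the series, first, only, none or still open, it means among the compounds named here.

Compound 3 `Brc1c(Br)c(Br)c2c(ncn2CCCn2nnnc2-c2ccccc2)c1Br` stands lowest of the three compounds measured in a functional assay on CCRF-CEM cells (Homo sapiens) for cytotoxicity, read by MTT assay, with a stated time of 48 h, tested at 10 uM; on this read-out lower numbers stand for a stronger effect and higher numbers for a weaker effect at the one concentration tested: compound 3 gives 57%, whereas compound 2 `Clc1ccccc1-c1nnn(CCCn2cnc3c(Br)c(Br)c(Br)c(Br)c32)n1` gives 104% and compound 1 `Brc1c(Br)c(Br)c2c(ncn2CCCn2nnc(-c3ccccc3)n2)c1Br` gives 105%, each beyond the scatter from compound 3. Compound 4 `Clc1ccccc1-c1nnnn1CCCn1cnc2c(Br)c(Br)c(Br)c(Br)c21` differs from compound 3 in one place only: chloro in place of hydrogen on an aromatic carbon. The same change has been measured once within the series, as a number 1 percentage points lower from compound 1 to compound 2 (within the scatter), a step within the scatter. On that single precedent no shift beyond the scatter is expected in this assay, and the step of a number 1 percentage points higher from compound 3 to compound 4 (within the scatter) is the estimate here. Compound 4 is therefore expected to read close to compound 3, at 58%, with a range from 44% to 74%.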

Compound 4, a percentage reported as inhibition, at one concentration (the size of the read-out at that concentration, not a potency): 51%
Compound 4: the middle estimate sits 7 percentage points above what was measured, within the range that was stated.
By their numbers in this assay, from the lowest: compounds 4 and 3 (each within the scatter of the next); then compounds 2 and 1 (each within the scatter of the next).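

In this assay, phenyl to 2-chlorophenyl now has a reading on a second core, with a step of a number 6 percentage points lower from compound 3 to compound 4 (within the scatter). Chloro on this aromatic carbon, ortho to a large group, therefore gives no shift beyond the scatter on either core, so the earlier null result is not confined to the core of compound 1. The two steps agree: the same change on two cores in this assay, a number 1 percentage points lower (within the scatter) from compound 1 to compound 2 and a number 6 percentage points lower (within the scatter) from compound 3 to compound 4, 5 percentage points apart, within the scatter of two such steps

Still open, from the compounds shown here alone, is whether an amine, a methoxy group or a carboxylic acid at this place would move the read-out. Also open, going by these compounds, is whether chloro at another carbon of the phenyl ring would behave the same way.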